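The compounds below may be only part of what the source reports. "The series", "measured", "known", "first", "only" and "open" are said of these compounds alone.

Working notes on the series. In a functional assay on MDA-MB-231 cells (Homo sapiens) for antiproliferative activity, read by MTT assay, with a stated time of 72 h (a lower number here means a stronger inhibitor, a higher number a weaker inhibitor), compound 1 (`COc1cc(-c2nccn2CC(C)C)cc(OC)c1OC`) gives > 100000 nM, a limit of the assay and not a number. As far as these compounds go, compound 2 (`COc1cc(-c2nccn2S(=O)(=O)c2ccccc2)cc(OC)c1OC`) gives > 100000 nM, likewise only a limit, so its true position is unknown. Both results sit at the same point: the limit of > 100000 nM in this assay, at which 2 of the 2 values shown sit. Compound 3 (`COc1cc(-c2nccn2S(=O)(=O)c2ccc(C)cc2)cc(OC)c1OC`) carries methyl in place of hydrogen on an aromatic carbon of the phenyl group of compound 2: methyl in place of hydrogen on an aromatic carbon. For the measured compounds named here, no measured step is available to scale this change. In this assay, the estimated a number no higher from compound 2 to compound 3 (the limit leaves the size open) is expected to stay within the scatter, with no direction favoured. For compound 3 the expected value is 100000 nM, with an estimated range of 40000 nM to 250000 nM.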

Compound 3, half-maximal inhibitory concentration: > 100000 nM
Compound 3: no number, only a limit; the forecaster's own chance of this, stated with the estimate: 70%; the middle value sits exactly at the limit.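

No step can be read from compound 2 to compound 3, because both results are limits and not numbers: the limit of > 100000 nM in this assay, at which 3 of the 3 values shown sit. The compounds shown leave open what effect, if any, the methyl group of compound 3 has.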